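Swapping an aryl amide for a small heterocycle: cytotoxicity

A few compounds are considered here, and "the series" means these few. Any claim that something is new, unique, unknown or untested is made for them only; others in the source may bear on it.

Measured compounds:
compound 1 `COc1ccc(-n2c(SC(C)C(=O)Nc3nc(C)c(Br)cc3Br)nc3ccccc32)cc1`: 9700 nM
compound 2 `COc1ccc(-n2c(S[C@H](C)C(=O)Nc3ccc(C)cc3Cl)nc3ccccc32)cc1`: > 75000 nM

Both compounds share one core and differ only in the group attached to the amide nitrogen. Among the measured compounds shown here, in an ADME assay on Vero cells (Chlorocebus sabaeus) for cytotoxicity, read by MTT assay, with a stated time of 24 h (a lower number here means that less compound is tolerated, a higher number that more compound is tolerated), compound 1 gives 9700 nM, the only definite number in this set. Compound 2 gives > 75000 nM in this assay, which is a limit of the assay rather than a number. So (the limit of > 75000 nM in this assay, at which 1 of the 2 values shown sits), and compound 1 stands as the one compound for which a real value is known.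

Compound 3 `COc1ccc(-n2c(SC(C)C(=O)Nc3cc(C)no3)nc3ccccc32)cc1` has not yet been measured in this assay. It differs from compound 1 in one place: 3-methyl-1,2-oxazol-5-yl in place of 3,5-dibromo-6-methylpyridin-2-yl on an amide-type nitrogen. For the measured compounds named here, no step between two measured compounds with a comparable change exists here, so the direction can only be guessed. Compound 3 is expected to be tolerated somewhat better than compound 1, an estimated step of a 3.1-fold higher number from compound 1 to compound 3 (0.49 log units; beyond the scatter), with a fair chance that only a limit is reported. The expected value for compound 3 is 30000 nM, within a range from 8000 nM to 75000 nM.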

Compound 3, half-maximal cytotoxic concentration: > 75000 nM
Compound 3: a limit, no number; the forecaster's own chance of this, stated with the estimate: 35%; middle value at least 2.5-fold (0.39 log units) away from the limit.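

Among the compounds shown here, this is the first step between measured compounds that differ in one place, and it shows that the group on the amide-type nitrogen alone can shift tolerance by more than the usual scatter. In this assay, putting 3-methyl-1,2-oxazol-5-yl in place of 3,5-dibromo-6-methylpyridin-2-yl gives an at least 7.7-fold higher number from compound 1 to compound 3 (0.88 log units; beyond the scatter). The value of compound 3 is a limit of the assay and not a number, so the full size of this step cannot be read: the limit of > 75000 nM in this assay, at which 2 of the 3 values shown sit.

The swap changes the ring and removes both bromine atoms at once, so the compounds shown leave open which of these changes accounts for the step. A pyridin-2-yl group without bromine on the same nitrogen could separate the two, and it might also show how much tolerance is tied to the bromine atoms.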